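The source may hold more compounds than are shown below. What is called first, only, known or untested is meant among the compounds shown, and "the series" means these compounds.

Compound 1 `CC(C)N(Cc1cccc(OCCCCCC(=O)O)c1)C(=O)c1ccc(-c2cccc(-c3ccccc3)c2)cc1`: in an ADME assay on BJ cells (Homo sapiens) for cytotoxicity, read by CellTiter-Glo and resazurin assay, with a stated time of 72 h (on this read-out higher numbers stand for an effect only at larger amounts of compound and lower numbers for an effect already at smaller amounts), compound 1 gives > 26000 nM, a limit of the assay rather than a number.
Compound 2 `CC(=O)c1cccc(-c2ccc(C(=O)N(Cc3cccc(OCCCCCC(=O)O)c3)C(C)C)cc2)c1`: compound 2 gives > 26000 nM, again only a limit.
Compound 3 `CC(C)N(Cc1cccc(OCCCCCC(=O)O)c1)C(=O)c1ccc(-c2cccc(F)c2)cc1`: compound 3 gives > 26000 nM, also a limit.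

Compound 3 thus stands at the limit, with no number of its own, and all three values sit at the limit of > 26000 nM in this assay, at which 3 of the 3 values shown sit. Compound 4 `CC(C)N(Cc1cccc(OCCCCCC(=O)O)c1)C(=O)c1ccc(-c2cccc(Br)c2)cc1` differs from compound 3 by bromo in place of fluoro on an aromatic carbon. The steps that touch this position, a step that the two limits leave unreadable from compound 1 to compound 3 and a step that the two limits leave unreadable from compound 2 to compound 3, bear on the change but give no readable size, since every value rests at the limit of > 26000 nM in this assay, at which 3 of the 3 values shown sit. In this assay no step beyond the scatter is therefore expected, the estimated step being a step that the limit leaves unreadable from compound 3 to compound 4. Compound 4 is estimated at 40000 nM, in the range 20000 nM to 100000 nM, most likely reported once more only as a limit.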

Compound 4, half-maximal effective concentration: > 26000 nM
Compound 4: a limit, no number; the forecaster's own chance of this, stated with the estimate: 85%; the middle value lies beyond the limit too.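

No step from compound 1, compound 2 or compound 3 to compound 4 can be read in this assay: the limit of > 26000 nM in this assay, at which 4 of the 4 values shown sit.

The compounds shown leave open whether the four groups compared at this position differ at all in this read-out, and at what amount any of these compounds would take effect.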